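From a Hydroxy to a Methoxy on the Core

The source may report more compounds than this note shows. Statements on the series, on what has been measured and on what is new or still open speak of the compounds shown alone.

compound 1 `COc1cc(C(=O)c2ccc(OC)c(O)c2OC)cc(OC)c1O`: 4990 nM
compound 2 `COc1cc(C(=O)c2ccc3c(c2)oc(=O)n3S(C)(=O)=O)cc(OC)c1OC`: 5380 nM

Both compounds were tested in a functional assay on NCI-H322M cells (Homo sapiens) for cytotoxicity, read by sulforhodamine B assay, with a stated time of 48 h (a lower number here means a stronger inhibitor of growth, a higher number a weaker inhibitor of growth), and give nearly the same reading. Compound 1 (4990 nM) and compound 2 (5380 nM) lie within the usual scatter of each other, so neither is set apart from the other on these numbers.

Compound 3 `COc1ccc(C(=O)c2cc(OC)c(OC)c(OC)c2)c(OC)c1O` has not yet been measured. It departs from compound 1 by a single change methyl in place of hydrogen on an oxygen on an aromatic ring with methyl in place of hydrogen on an oxygen on an aromatic ring, which also reads as hydroxy to methoxy. For the measured compounds named here, no two measured compounds differ in just one place, so the data offer no direct guide to the size of this step. Even so, a clear step towards a lower number in this assay is expected, although a result within the scatter remains possible. The estimated shift is an 8.3-fold lower number from compound 1 to compound 3 (0.92 log units; beyond the scatter) in that direction. Compound 3 is therefore expected at 600 nM (estimated range 60 nM to 6000 nM).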

Compound 3, concentration for 50% growth inhibition: < 10 nM
Compound 3: no number, only a limit; the forecaster's own chance of this, stated with the estimate: 5%; middle value at least 60-fold (1.77 log units) from the limit.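

In this assay, for the compounds shown here, methyl in place of hydrogen on an oxygen on an aromatic ring gives an at least 490-fold lower number from compound 1 to compound 3 (2.69 log units; beyond the scatter), the first step that can be read at a single place, and it shows that this one oxygen carries a large part of the difference in growth inhibition. The earlier pair of compounds could not show this, as compound 1 and compound 2 differ in more than one place and their readings lie within the scatter of each other. The reading for compound 3, < 10 nM, is a limit of the assay and not a number, so the step gives only the smallest size it can have, and its full size cannot be read: the limit of < 10 nM in this assay, at which 1 of the 3 values shown sits.

What the compounds shown leave open is how other groups on this oxygen would read, such as an ethoxy group, a longer chain or a carboxylic acid on a short chain, or an amine in place of the oxygen. They also leave open whether the same change at the hydroxy that compound 3 still carries would shift the reading, and whether this single step would hold on another core.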